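A few compounds are considered here, and "the series" means these few. Any claim that something is new, unique, unknown or untested is made for them only; others in the source may bear on it.

Measured compounds:
compound 1 `COc1cc(NC(C)CCCNC(=O)Nc2cccc(F)c2)c2ncccc2c1` — 19000 nM
compound 2 `COc1cc(NC(C)CCCNC(=O)Nc2ccc(Br)cc2)c2ncccc2c1` — 18000 nM
compound 3 `COc1cc(NC(C)CCCNC(=O)NNC(=O)Nc2ccc(O)cc2)c2ncccc2c1` — 95000 nM

All three were tested in a functional assay on L1210 cells (Mus musculus) for inhibition, read by MTT assay, with a stated time of 72 h; on this read-out higher numbers stand for weaker inhibition and lower numbers for stronger inhibition. Compound 1 sits at the second highest of the three numbers; compound 2 is nearest, a 1.1-fold lower number from compound 1 to compound 2 (0.02 log units; within the scatter), and compound 3 furthest, a 5.0-fold higher number from compound 1 to compound 3 (0.70 log units; beyond the scatter). The next step goes from compound 1 to compound 4 `COc1cc(NC(C)CCCNC(=O)Nc2ccc(O)cc2)c2ncccc2c1`, with the change (4-hydroxyphenyl in place of 3-fluorophenyl on an amide-type nitrogen).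

For the measured compounds named here, no measured step carries this exact change. The closest bearing is compound 3, where a 4-hydroxyphenyl enters through a longer linker, and the numbers rise, a 5.0-fold higher number from compound 1 to compound 3 (0.70 log units; beyond the scatter) and a 5.3-fold higher number from compound 2 to compound 3 (0.72 log units; beyond the scatter). Changing the ring substituent alone left things flat, a 1.1-fold lower number from compound 1 to compound 2 (0.02 log units; within the scatter). For compound 4 a small rise is therefore expected, mostly within the scatter, a 1.3-fold higher number from compound 1 to compound 4 (0.12 log units; within the scatter). Compound 4 is estimated at 25000 nM, range 11000 nM to 60000 nM.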

Compound 4, half-maximal inhibitory concentration: 21000 nM
Compound 4: the middle estimate sits 1.2-fold (0.08 log units) above what was measured; low and high end bracket the measured number.
By their numbers in this assay, from the lowest: compounds 2, 1 and 4 (each within the scatter of the next); then compound 3.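

In this assay, this position on the amide-type nitrogen accepts a hydroxy-bearing ring with no reading change: 4-hydroxyphenyl for 3-fluorophenyl gives a 1.1-fold higher number from compound 1 to compound 4 (0.04 log units; within the scatter), and hydroxy for bromo gives a 1.2-fold higher number from compound 2 to compound 4 (0.07 log units; within the scatter). The 4-hydroxyphenyl alone therefore does not account for the high number of compound 3, since 4-hydroxyphenyl in place of ((4-hydroxyphenyl)carbamoyl)amino gives a 4.5-fold lower number from compound 3 to compound 4 (0.66 log units; beyond the scatter). No evidence is available to explain these readings.

Open, on these data alone, is whether an amine or a carboxylic acid on this ring would move the number beyond the scatter. As far as these compounds go, a plain alkyl chain in place of the ring also remains open.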